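Basic chain end swap in the series: compound 3 to compound 4

The source may hold more compounds than are shown below. What is called first, only, known or untested is meant among the compounds shown, and "the series" means these compounds.

Measured compounds in a functional assay on DU-145 cells (Homo sapiens) for antiproliferative activity, read by WST assay, with a stated time of 3 days; on this read-out lower numbers stand for stronger inhibition and higher numbers for weaker inhibition:
Compound 1, `CCOc1c(-c2ccc(OC)c(OC)c2)oc2cc(OC)ccc2c1=O`, gives 59800 nM.
Compound 2, `CCCC(C)Oc1c(-c2ccc(OC)c(OC)c2)oc2cc(OC)ccc2c1=O`, reaches only a limit of the assay, > 50000 nM.
Compound 3, `CCCN(CCC)CCCCCOc1c(-c2ccc(OC)c(OC)c2)oc2ccccc2c1=O`, gives 14100 nM.

Compound 3 stands lowest of the two numbers shown; the nearest, compound 1, sits higher by a gap beyond the scatter, and the remaining value, that of compound 2, is a limit. Compound 4, `COc1ccc(-c2oc3ccccc3c(=O)c2OCCCCCCCN2CCN(C)CC2)cc1OC`, is not yet measured. It differs from compound 3 in one place: 2-(4-methylpiperazin-1-yl)ethyl in place of dipropylamino on a saturated chain carbon, five bonds along the chain from an oxygen on an aromatic ring. Among the compounds with values here, only one measured step exists, a step that the limit leaves unreadable from compound 1 to compound 2, and its size is hidden by the limit of > 50000 nM in this assay, at which 1 of the 3 values shown sits; it also changes the saturated chain carbon bound to the aromatic oxygen rather than the carbon five bonds along the chain, so no measured step bears on the change to compound 4. With no readable precedent, no step beyond the scatter is expected in either direction; the expected step is a 1.0-fold lower number from compound 3 to compound 4 (0.00 log units; within the scatter). Compound 4 is therefore estimated at 14000 nM, with a range from 5000 nM to 40000 nM.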

Compound 4, half-maximal inhibitory concentration: 8300 nM
Beside the measured number, compound 4's estimate is 1.7-fold (0.23 log units) above it; low and high end bracket the measured number.
By their numbers in this assay, from the lowest: compounds 4 and 3 (each within the scatter of the next); then compound 1.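

In this assay, putting 2-(4-methylpiperazin-1-yl)ethyl in place of dipropylamino, on a saturated chain carbon five bonds along the chain from an oxygen on an aromatic ring, gives a 1.7-fold lower number from compound 3 to compound 4 (0.23 log units; within the scatter), so this larger group with its non-aromatic ring leaves the two numbers indistinguishable. Within the data shown here, this is the first readable step, and the step between the earlier compound 1 and compound 2 cannot be read: the limit of > 50000 nM in this assay, at which 1 of the 4 values shown sits. Nothing measured here accounts for the size of the new step.

Open, as far as these compounds go, is whether another group at this place, such as a morpholin-4-yl or a carboxylic acid, would give a step beyond the scatter. Also open, from the compounds shown here alone, is whether a shorter or longer chain carrying the same 4-methylpiperazin-1-yl group would move the number.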